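Shortening the Chain on a Weak Cell-Growth Inhibitor

This account rests on a few compounds, and the source may have more. Where it says the series, first, only, none or still open, it means among the compounds named here.

Measured compounds:
compound 1, `CCCCCCCCCCOP(=O)(O)OCCSC(=S)N1CCCC1` — 70000 nM
compound 2, `CCCCCCCCCCOP(=O)(O)OCCSC(=S)N1CCN(C)CC1` — 99600 nM

In a functional assay on MCF7 cells (Homo sapiens) for inhibition, read by MTT assay, with stated times of 18 h and 4 h (on this read-out lower numbers stand for stronger inhibition and higher numbers for weaker inhibition), compound 1 gives 70000 nM, and compound 2 gives 99600 nM. For the measured compounds named here, compound 1 carries the lowest of the two numbers, but the only measured step, a 1.4-fold higher number from compound 1 to compound 2 (0.15 log units; within the scatter), stays within the scatter, so the two compounds cannot be told apart on this read-out. That step swaps the group on the thiocarbonyl carbon and leaves the long chain on the phosphate oxygen untouched.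

Compound 3, `CCCCCCOP(=O)(O)OCCSC(=S)N1CCCC1`, differs from compound 1 in exactly that chain: hydrogen in place of butyl on a saturated chain carbon, six bonds along the chain from an oxygen on an unsaturated carbon. Going by the values given here, no measured step bears on a change of this kind, so the two values above offer no guide to its size or direction; the expectation rests on the value of compound 1 alone, with wide uncertainty. A shorter chain is expected to give a higher number, that is weaker inhibition, so the step of a 1.7-fold higher number from compound 1 to compound 3 (0.23 log units; within the scatter) is expected. For compound 3 the estimate is 120000 nM, with a range from 40000 nM to 400000 nM.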

Compound 3, half-maximal inhibitory concentration: 100000 nM
For compound 3 the middle estimate is 1.2-fold (0.08 log units) above the measured one; low and high end bracket the measured number.
By their numbers in this assay, from the lowest: compounds 1, 2 and 3 (each within the scatter of the next).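

Swapping butyl for hydrogen at this place, six bonds along the chain from an oxygen on an unsaturated carbon, gives a 1.4-fold higher number from compound 1 to compound 3 (0.15 log units; within the scatter) in this assay, so the two cannot be told apart on this read-out. This step tests the chain on the phosphate oxygen, whereas the step between compound 1 and compound 2 touched only the group on the thiocarbonyl carbon. Taking away these four carbons, a sizeable cut to the chain, therefore leaves no difference that stands beyond the usual scatter of repeated measurements, and no other measurement is at hand to explain this result.

Going by these compounds, a single shortening cannot show whether the chain matters at all, so a shorter chain such as propyl or ethyl, a longer chain, and a chain ending in an amine or a carboxylic acid all remain open. Also open, on these data alone, is whether the same loss of butyl would read the same with 4-methylpiperazin-1-yl on the thiocarbonyl carbon in place of pyrrolidin-1-yl.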